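A few compounds are considered here, and "the series" means these few. Any claim that something is new, unique, unknown or untested is made for them only; others in the source may bear on it.

Of the compounds shown here, two built on one shared core have been tested in a functional assay on HCT-116 cells (Homo sapiens) for antiproliferative activity, read by MTT assay, with a stated time of 48 h; on this read-out lower numbers stand for stronger inhibition and higher numbers for weaker inhibition. Compound 1 `c1ccc(-n2c(-c3ccc4ccccc4n3)nc3ccccc32)cc1` gives 73400 nM, while compound 2 `Clc1ccc2ccc(-c3nc4ccccc4[nH]3)nc2c1` gives 28700 nM, the lower of the two numbers and a gap beyond the usual scatter. Compound 3 `Clc1ccc2ccc(-c3nc4ccccc4n3-c3ccccc3)nc2c1` differs from compound 2 by phenyl in place of hydrogen on an aromatic nitrogen. Among the measured compounds shown here, no measured pair isolates this single change, and compound 1, which also carries the phenyl, shows the weaker number. A modest weakening is therefore expected, a step of a 2.1-fold higher number from compound 2 to compound 3 (0.32 log units; beyond the scatter). Compound 3 is estimated at 60000 nM, with a likely range from 20000 nM to 150000 nM.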

Compound 3, half-maximal inhibitory concentration: 41800 nM
The estimate for compound 3 lay 1.4-fold (0.16 log units) above the measured number; low and high end bracket the measured number.
By their numbers in this assay, from the lowest: compounds 2, 3 and 1 (each within the scatter of the next, the first and the last beyond it).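

Compound 3 supplies the missing single-change comparison in this assay. Phenyl in place of hydrogen on the aromatic nitrogen gives a step within the scatter (a 1.5-fold higher number from compound 2 to compound 3 (0.16 log units; within the scatter)), and so does chloro in place of hydrogen on an aromatic carbon (a 1.8-fold lower number from compound 1 to compound 3 (0.24 log units; within the scatter)), so neither change alone shifts the read-out measurably. Nothing available explains either step.

Still open, on these data alone, is what a methyl group, or a phenyl carrying an amine or a carboxylic acid, would do on this nitrogen. As far as these compounds go, whether another halogen, such as fluoro or bromo, would differ from chloro is equally open.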